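Swapping methyl for 4-methoxybenzyl on compound 3

The source may hold more compounds than are shown below. What is called first, only, known or untested is meant among the compounds shown, and "the series" means these compounds.

In a functional assay on cells (Leukemia cell, Homo sapiens) for cytotoxicity, with a stated time of 48 h (on this read-out lower numbers stand for stronger inhibition of growth and higher numbers for weaker inhibition of growth), compound 3 `COc1ccc2c(c1)/C(=C\c1cc(OC)c(OC)c(OC)c1)C(=O)N2C` gives 7600 nM and compound 2 `COc1cc(/C=C2/C(=O)N(C)c3ccc(O)cc32)cc(OC)c1OC` gives 8300 nM, so the two sit together at the low end of the numbers. Compound 1 `COc1ccc(CN2C(=O)/C(=C\c3cc(OC)c(OC)c(OC)c3)c3ccccc32)cc1` gives a clearly higher 27500 nM. Compound 4 `COc1ccc(CN2C(=O)/C(=C/c3cc(OC)c(OC)c(OC)c3)c3cc(OC)ccc32)cc1` differs from compound 3 by 4-methoxyphenyl in place of hydrogen on a saturated chain carbon bound to an amide-type nitrogen in a ring, which turns a methyl into a 4-methoxybenzyl. Going by the values given here, the only measured single change, a 1.1-fold lower number from compound 2 to compound 3 (0.04 log units; within the scatter), concerns a methyl on an oxygen on an aromatic ring, not this place, so it says little here. Among the measured compounds only compound 1 carries 4-methoxybenzyl, and its 27500 nM hints at weaker growth inhibition, though this is a single case. The expected change is a 2.1-fold higher number from compound 3 to compound 4 (0.32 log units; beyond the scatter). The estimate for compound 4 is 16000 nM, with an expected range from 6000 nM to 45000 nM.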

Compound 4, concentration for total growth inhibition: 27500 nM
Beside the measured number, compound 4's estimate is 1.7-fold (0.24 log units) below it, and the stated range covers the measured number.
By their numbers in this assay, from the lowest: compounds 3 and 2 (each within the scatter of the next); then compounds 1 and 4 (each within the scatter of the next).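

Changing the methyl on compound 3 to 4-methoxybenzyl, on the carbon bound to the amide-type nitrogen in a ring, gives in this assay a 3.6-fold higher number from compound 3 to compound 4 (0.56 log units; beyond the scatter). Going by these compounds alone, this is the first direct reading at this place, and it shows that growth inhibition weakens with this swap, on a core that also carries the ring methoxy of compound 3. Nothing available explains the shift. Still open, going by these compounds, is how an ethyl or an unsubstituted benzyl would read at this place. A chain ending in an amine is open too.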